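Chloro for bromo at the hydrazide end of the series

The source may hold more compounds than are shown below. What is called first, only, known or untested is meant among the compounds shown, and "the series" means these compounds.

Compound 1 `NNC(=O)c1c(NC(=O)NS(=O)(=O)c2ccccc2)sc2c1CCCCC2` gives 15800 nM in a functional assay on cells (Cancer cell lines, Homo sapiens) for inhibition, with a stated time of 48 h; a lower number here means a stronger inhibitor of growth, a higher number a weaker inhibitor of growth. Going by the values given here, compound 2 `CN1CCN(C(=O)c2c(NC(=O)NS(=O)(=O)c3ccccc3)sc3c2CCCCC3)CC1` gives 80200 nM in this assay, and the change a 5.1-fold higher number from compound 1 to compound 2 (0.71 log units; beyond the scatter) is the only step in this set with a number at both ends. Compound 3 `O=C(Nc1sc2c(c1C(=O)NNc1ccc(Br)cc1)CCCCC2)NS(=O)(=O)c1ccccc1` is reported in this assay only as a limit, > 100000 nM. That limit of > 100000 nM in this assay, at which 1 of the 3 values shown sits, makes compound 3 the end point of two one-place steps, an at least 6.3-fold higher number from compound 1 to compound 3 (0.80 log units; beyond the scatter) and an at least 1.2-fold higher number from compound 2 to compound 3 (0.09 log units; that floor lies within the scatter), so compound 3 stands at the weak edge of what is known, with no number of its own.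

Compound 4 `O=C(Nc1sc2c(c1C(=O)NNc1ccc(Cl)cc1)CCCCC2)NS(=O)(=O)c1ccccc1` differs from compound 3 in one place: chloro in place of bromo on an aromatic carbon. Among the compounds with values here, no measured step swaps one halogen for another; the steps that bear on compound 4 are the two that lead into compound 3, and both end at the limit. Nothing in the measured steps points to a change beyond the scatter for the swap of chloro for bromo, so compound 4 is expected to sit where compound 3 does, most likely again at the limit. The estimate for compound 4 in this assay is 120000 nM, in the range 40000 nM to 350000 nM, which means an expected step that the limit leaves unreadable from compound 3 to compound 4.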

Compound 4, concentration for 50% growth inhibition: 14500 nM
Compound 4: the middle estimate sits 8.3-fold (0.92 log units) above what was measured; the whole stated range lies above it.
By their numbers in this assay, from the lowest: compounds 4 and 1 (each within the scatter of the next); then compound 2. At a limit, above all of these: compound 3.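

Compound 3 stands as a limit, not a number: the limit of > 100000 nM in this assay, at which 1 of the 4 values shown sits. In this assay, going by these compounds alone, chloro in place of bromo on an aromatic carbon, para to a large group, is the only halogen swap, and exchanging that single heavy atom gives an at least 6.8-fold lower number from compound 3 to compound 4 (0.83 log units; beyond the scatter), so this carbon is not indifferent to which halogen it carries. An aryl group on the terminal amine nitrogen therefore does not by itself carry compound 3 to the limit: 4-chlorophenyl in place of hydrogen gives a 1.1-fold lower number from compound 1 to compound 4 (0.04 log units; within the scatter), and ((4-chlorophenyl)amino)amino in place of 4-methylpiperazin-1-yl on the carbonyl carbon gives a 5.5-fold lower number from compound 2 to compound 4 (0.74 log units; beyond the scatter).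

Going by these compounds, the full size of the halogen step stays open, since only its floor can be read, and a single pair cannot show whether bromo is the exception or chloro is. Fluoro, methyl or methoxy on that aromatic carbon, or an unsubstituted phenyl, would show whether the response follows a trend or is confined to this pair.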